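This account rests on a few compounds, and the source may have more. Where it says the series, first, only, none or still open, it means among the compounds named here.

Three close relatives have been tested in an ADME assay on MT4 cells (Homo sapiens) for cytotoxicity, read by MTT assay; on this read-out higher numbers stand for lower toxicity in this test and lower numbers for higher toxicity in this test. Compound 1 `CCc1c(Cc2c(Cl)cccc2Cl)nc(SCC(=O)c2ccc(F)cc2)[nH]c1=O` reached only a limit, > 55000 nM. Compound 2 `Cc1c(Cc2c(F)cccc2F)nc(SCC(=O)c2ccc(F)cc2)[nH]c1=O` also reached only a limit, > 62000 nM. Compound 3 `CCc1c(Cc2c(F)cccc2F)nc(SCC(=O)c2ccccc2)[nH]c1=O` is the only one of the three with an actual number, 56000 nM, so it cannot be ranked against the other two.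

Compound 4 `CCc1c(Cc2c(F)cccc2F)nc(SCC(=O)c2ccc(F)cc2)[nH]c1=O` differs from compound 3 by a single change, fluoro in place of hydrogen on an aromatic carbon, which turns phenyl into 4-fluorophenyl. Compound 1 and compound 2 both carry that 4-fluorophenyl group, and neither gave a number in this assay, only limits. Among the compounds with values here, no pair of measured compounds isolates this change, so the expectation rests on that loose comparison. The step of a 1.0-fold higher number from compound 3 to compound 4 (0.02 log units; within the scatter) is expected to stay within the usual scatter, with no clear direction. For compound 4 the estimated value in this assay is 58000 nM, with an expected range of 32000 nM to 95000 nM, and a reading reported only as a limit would be no surprise.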

Compound 4, half-maximal cytotoxic concentration: > 60000 nM
Compound 4 gave a limit, no number; the forecaster's own chance of this, stated with the estimate: 60%; middle value at least 1.0-fold (0.01 log units) away from the limit.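

In this assay, the change from phenyl to 4-fluorophenyl can now be followed on its own, and it gives an at least 1.0-fold higher number from compound 3 to compound 4 (0.02 log units; that floor lies within the scatter). This shows that a fluoro on this aromatic carbon, para to a large group, can be carried without a lower number appearing in this test. Compound 4 gives only a limit, so the step has a floor but no readable size: the limit of > 60000 nM in this assay, at which 1 of the 4 values shown sits.

The steps linking compound 1 and compound 2 to compound 4 cannot be read, with limits at both ends. The compounds shown leave open how much higher the true number of compound 4 may lie, and whether a methoxy, an amine or a carboxylic acid at this same place would keep the read-out in the same range.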